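A few compounds are considered here, and "the series" means these few. Any claim that something is new, unique, unknown or untested is made for them only; others in the source may bear on it.

Measured compounds in a functional assay on UO-31 cells (Homo sapiens) for inhibition, read by sulforhodamine B assay, with a stated time of 48 h; on this read-out higher numbers stand for weaker inhibition of growth and lower numbers for stronger inhibition of growth:
compound 1 `O=C(Nc1cccc(-n2cc(-c3ccncc3)c(-c3ccc(Cl)c(O)c3)n2)c1)Nc1cccc(C(F)(F)F)c1` gives > 32500 nM, a limit of the assay.
compound 2 `COc1cc(-c2nn(-c3cccc(NC(=O)Nc4cc(C(F)(F)F)cc(C(F)(F)F)c4)c3)cc2-c2ccncc2)ccc1Cl` gives 1280 nM.
compound 3 `COc1cc(-c2nn(-c3cccc(NC(=O)c4cccc(C(F)(F)F)c4)c3)cc2-c2ccncc2)ccc1Cl` gives > 50000 nM, a limit of the assay.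

Compound 3 stands at the limit of > 50000 nM in this assay, at which 1 of the 3 values shown sits, so no number is known for it; its growth inhibition simply did not reach the range the assay reports. Compound 4 `COc1cc(-c2nn(-c3cccc(NC(=O)Nc4ccc(Cl)c(Cl)c4)c3)cc2-c2ccncc2)ccc1Cl` differs from compound 3 in one place: (3,4-dichlorophenyl)amino in place of 3-(trifluoromethyl)phenyl on a carbonyl carbon. The carbonyl of compound 3 thereby becomes part of a urea, as in compound 2, which shares the rest of its structure with compound 3 but carries a different aryl group on its urea. For the measured compounds named here, no step between two measured compounds that differ in only one place is available, so the size of this change can only be judged from compound 2, which as a urea gives 1280 nM in this assay. On that basis a large step toward stronger inhibition is expected, an at least 16-fold lower number from compound 3 to compound 4 (1.22 log units; beyond the scatter). Compound 4 is estimated at 3000 nM, with a likely range from 700 nM to 20000 nM, while a report of only a limit again remains possible.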

Compound 4, concentration for total growth inhibition: 4980 nM
Compound 4: the middle estimate sits 1.7-fold (0.22 log units) below what was measured; the measured number falls inside the stated range.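

In this assay, replacing 3-(trifluoromethyl)phenyl with (3,4-dichlorophenyl)amino on this carbonyl carbon gives an at least 10-fold lower number from compound 3 to compound 4 (1.00 log units; beyond the scatter). For the compounds shown here, this is the first step at this position that can be read directly, and it shows that, with the rest of the structure held constant, this change turns a compound without a reported number into one with a measurable value. The step is only a minimum, as compound 3 is reported solely as a limit: the limit of > 50000 nM in this assay, at which 1 of the 4 values shown sits.

The change adds an amino nitrogen and swaps the trifluoromethyl substituent for two chlorines at once, so the compounds shown leave open which of these accounts for the step. Also open, from the compounds shown here alone, is how this position would respond to a non-aromatic group, such as a cyclohexyl ring or a longer alkyl chain, on the urea.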